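From methoxycarbonyl to propyl on a carbonyl carbon

This account rests on a few compounds, and the source may have more. Where it says the series, first, only, none or still open, it means among the compounds named here.

Results in a functional assay on HUVEC cells (Homo sapiens) for inhibition; on this read-out higher numbers stand for weaker inhibition and lower numbers for stronger inhibition:
Compound 1 `COc1cc(/C=C/C(=O)c2cccc(NC(=O)c3c(Cl)cccc3Cl)c2)ccc1O`: 0.46 ug/mL
Compound 2 `COc1cc(/C=C/C(=O)c2cccc(NC(=O)c3cc(Cl)cc(Cl)c3)c2)ccc1O`: 0.75 ug/mL
Compound 3 `COC(=O)C(=O)Nc1cccc(C(=O)/C=C/c2ccc(O)c(OC)c2)c1`: 1.5 ug/mL

Compound 3 lies within the scatter of one neighbour, as a 2.0-fold higher number from compound 2 to compound 3 (0.30 log units; within the scatter) shows, but not of the other, as a 3.3-fold higher number from compound 1 to compound 3 (0.51 log units; beyond the scatter) shows. The two dichlorophenyl compounds do not separate, with a 1.6-fold higher number from compound 1 to compound 2 (0.21 log units; within the scatter). Compound 4 `CCCC(=O)Nc1cccc(C(=O)/C=C/c2ccc(O)c(OC)c2)c1` is the next case, with propyl in place of methoxycarbonyl on a carbonyl carbon. Neither of the steps into compound 3 tests propyl, and both of them involve dichlorophenyl groups, so they offer only a loose guide. No shift beyond the scatter is therefore expected, and the estimated step is a 1.2-fold lower number from compound 3 to compound 4 (0.06 log units; within the scatter). Compound 4 is expected at 1.3 ug/mL, within an estimated range of 0.6 ug/mL to 3 ug/mL.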

Compound 4, half-maximal inhibitory concentration: 1.27 ug/mL
For compound 4 the middle estimate is 1.0-fold (0.01 log units) above the measured one; the measured number falls inside the stated range.
By their numbers in this assay, from the lowest: compounds 1, 2, 4 and 3 (each within the scatter of the next, the first and the last beyond it).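

In this assay propyl can take the place of methoxycarbonyl, and so of both hydrogen-bond acceptors of that group, with a 1.2-fold lower number from compound 3 to compound 4 (0.07 log units; within the scatter) and no separation of the two compounds. Compound 4 gives a 1.7-fold higher number from compound 2 to compound 4 (0.23 log units; within the scatter) but a 2.8-fold higher number from compound 1 to compound 4 (0.44 log units; beyond the scatter) and thus, like compound 3, stands apart only from the 2,6-dichlorophenyl compound. No measurement at hand explains these results. The compounds shown leave open whether a longer chain, an amine or a carboxylic acid on this carbonyl carbon would group with compound 3 and compound 4 or with compound 1.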